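The source may hold more compounds than are shown below. What is called first, only, known or untested is meant among the compounds shown, and "the series" means these compounds.

Compound 1 `Nc1ccc(Nc2c(C(=O)NCc3ccc(F)cc3)nc(Br)c3cccnc23)cc1`: in a functional assay on HT-29 cells (Homo sapiens) for cytotoxicity, read by MTT assay, with a stated time of 72 h (on this read-out lower numbers stand for stronger inhibition and higher numbers for weaker inhibition), compound 1 gives > 10000 nM, which is a limit of the assay and not a number.
Compound 2 `COC(=O)CNc1c(C(=O)NCc2ccc(F)cc2)nc(Br)c2cccnc12`: in this assay compound 2 gives > 10000 nM, again a limit of the assay.
Compound 3 `NCCCNc1c(C(=O)NCc2ccc(F)cc2)nc(Br)c2cccnc12`: in this assay compound 3 gives "not determined" (no result reported), so no result is reported for it.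

Among the measured compounds shown here, compound 2 stands at a limit in this assay, and the only step that connects it to another measured compound, a step that the two limits leave unreadable from compound 1 to compound 2, runs between two limits and cannot be read in size or direction. For the measured compounds named here, the single point of evidence, (the limit of > 10000 nM in this assay, at which 2 of the 3 values shown sit), says only that both measured compounds sit at the same limit.

The account now turns to compound 4 `CN(C)CCCNc1c(C(=O)NCc2ccc(F)cc2)nc(Br)c2cccnc12`, which differs from compound 2 as follows: 2-(dimethylamino)ethyl in place of methoxycarbonyl on a saturated chain carbon bound to a nitrogen on an aromatic ring. No measured step bears on this change, since the one step shown, from compound 1 to compound 2, is unreadable and concerns a different part of the chain, and compound 3 carries no result. With both measured compounds at the limit, the expectation for compound 4 can only be anchored to that limit, with a wide range in both directions. Compound 4 is therefore estimated at 12000 nM in this assay, from 2000 nM to 60000 nM. The step expected from compound 2 to compound 4 is a step that the limit leaves unreadable from compound 2 to compound 4.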

Compound 4, half-maximal inhibitory concentration: 6000 nM
Compound 4: the middle estimate sits 2.0-fold (0.30 log units) above what was measured; the measured number falls inside the stated range.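

In this assay, compound 4 is the only compound shown that gives a number rather than a limit or no result, at 6000 nM, so a chain ending in dimethylamino gives this position its first readable value. On a saturated chain carbon bound to a nitrogen on an aromatic ring, 2-(dimethylamino)ethyl in place of methoxycarbonyl gives an at least 1.6-fold lower number from compound 2 to compound 4 (0.22 log units; that floor lies within the scatter), and 3-(dimethylamino)propyl in place of 4-aminophenyl on that nitrogen gives an at least 1.6-fold lower number from compound 1 to compound 4 (0.22 log units; that floor lies within the scatter). Each of these steps starts from a limit of the assay, so each gives only a floor and not a measured size, and since both floors lie within the scatter, neither change is yet shown to move the value beyond it.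

Going by these compounds, it remains open whether a shorter or longer chain, such as 2-(dimethylamino)ethyl or 4-(dimethylamino)butyl on the nitrogen, or a morpholine at the end of the propyl chain, would give a value clearly apart from that limit. Compound 3 gives "not determined" (no result reported), so the primary amine offers no comparison with the dimethylamino end of compound 4, and most of the measured compounds still give no number: the limit of > 10000 nM in this assay, at which 2 of the 4 values shown sit.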